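Replacing 1-methylethenyl with oxolan-2-yl: compound 3

The compounds below may be only part of what the source reports. "The series", "measured", "known", "first", "only" and "open" are said of these compounds alone.

Measured so far:
Compound 1, `CC(C)C/N=C(\NC#N)Nc1cccnc1`: in a functional assay on the whole organism (blood, strain Wistar-Okamoto) with Rattus norvegicus as the target, with a stated time of 5 days (on this read-out higher numbers stand for an effect only at larger amounts of compound and lower numbers for an effect already at smaller amounts), compound 1 gives 20 mg/kg.
Compound 2, `C=C(C)C/N=C(\NC#N)Nc1cccnc1`: in this assay compound 2 gives 20 mg/kg.

Compound 2 stands level with compound 1 at the digits shown; the only measured step, no change at the digits printed from compound 1 to compound 2 (within the scatter), shows that exchanging one branched three-carbon group for another on the saturated chain carbon bound to the double-bonded nitrogen left the read-out unchanged within the scatter.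

Compound 3, `N#CN/C(=N\CC1CCCO1)Nc1cccnc1`, is not yet measured. It differs from compound 2 as follows: oxolan-2-yl in place of 1-methylethenyl on a saturated chain carbon bound to a double-bonded nitrogen.

Within the data shown here, the one measured step bears on this position but not on this kind of change: it tells only that the group on that saturated chain carbon can be varied between two branched three-carbon groups without moving the read-out. Among the measured compounds shown here, the ring and the extra hydrogen-bond acceptor of oxolan-2-yl have no counterpart in the measured pair, so the step is hard to anticipate. For the measured compounds named here, on the single step on hand, compound 3 is expected to stay near compound 2, with the expected step of no change at the digits printed from compound 2 to compound 3 (within the scatter) lying within the scatter. The estimate for compound 3 in this assay is 20 mg/kg, with a range from 7 mg/kg to 60 mg/kg.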

Compound 3, minimum effective dose: 50 mg/kg
The estimate for compound 3 lay 2.5-fold (0.40 log units) below the measured number; the measured number falls inside the stated range.
By their numbers in this assay, from the lowest: compounds 1 and 2 (each within the scatter of the next); then compound 3.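

In this assay, the group on the saturated chain carbon bound to a double-bonded nitrogen turns out not to be freely exchangeable: oxolan-2-yl in place of 1-methylethenyl gives a 2.5-fold higher number from compound 2 to compound 3 (0.40 log units; beyond the scatter) and oxolan-2-yl in place of isopropyl gives a 2.5-fold higher number from compound 1 to compound 3 (0.40 log units; beyond the scatter) in equal measure. Among these compounds, the earlier pair showed only that two branched three-carbon groups could replace each other within the scatter, whereas this modest step shows that a group with a five-membered non-aromatic ring and a hydrogen-bond acceptor takes the effect to a larger amount of compound. Nothing available explains this shift.

Going by these compounds, compound 3 brings in the ring and the oxygen together, so it remains open which of the two goes with the step; cyclopentyl would carry the ring without the oxygen, and methoxymethyl the oxygen without the ring. Also open is how the read-out would respond to an amine or a longer chain on the same carbon, since the three compounds shown cover only isopropyl, 1-methylethenyl and oxolan-2-yl.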